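A Hydroxyethylamine in Place of the Chloride of Compound 1

The source may report more compounds than this note shows. Statements on the series, on what has been measured and on what is new or still open speak of the compounds shown alone.

Compound 1 `Nc1nn2c(O)cc(CCl)nc2c1[N+](=O)[O-]`: in a functional assay on K562 cells (Homo sapiens) for inhibition (a lower number here means a stronger inhibitor of growth, a higher number a weaker inhibitor of growth), compound 1 gives > 50 ug/mL, which is a limit of the assay and not a number.
Compound 2 `COc1ccc(NNCc2cc(O)n3nc(N)c([N+](=O)[O-])c3n2)cc1`: in this assay compound 2 gives 5.1 ug/mL.
Compound 3 `Nc1nn2c(O)cc(CNNc3ccc(S(=O)(=O)O)cc3)nc2c1[N+](=O)[O-]`: in this assay compound 3 gives > 50 ug/mL, which is a limit of the assay.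

Compound 1 therefore stands at the edge of what this assay can report, and only compound 2 has a real number; the other two sit at the limit of > 50 ug/mL in this assay, at which 2 of the 3 values shown sit. Compound 4 `Nc1nn2c(O)cc(CNCCO)nc2c1[N+](=O)[O-]` differs from compound 1 in one place: (2-hydroxyethyl)amino in place of chloro on a saturated chain carbon bound to an aromatic carbon. Among the compounds with values here, no measured pair carries this change. Within the data shown here, the one measured step, an at least 9.8-fold higher number from compound 2 to compound 3 (0.99 log units; beyond the scatter), concerns a different position and shows only how far the numbers in this set can move. Compound 4 is expected to stay weak, with an estimate of 30 ug/mL and a range from 8 ug/mL to 100 ug/mL. Since compound 1 has only a limit, the expected step of an at least 1.6-fold lower number from compound 1 to compound 4 (0.22 log units; that floor lies within the scatter) cannot be given a firm size or direction.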

Compound 4, concentration for 50% growth inhibition: > 50 ug/mL
Compound 4: only a limit was reported; the forecaster's own chance of this, stated with the estimate: 55%; at least 1.6-fold (0.22 log units) between middle value and limit.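

Within the data shown here, compound 1 and compound 4 both end at a limit of the assay and not at a number, so no step between them can be read: the limit of > 50 ug/mL in this assay, at which 3 of the 4 values shown sit. The compounds shown leave open whether (2-hydroxyethyl)amino in place of chloro changes growth inhibition at all, and in which direction.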